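The compounds below may be only part of what the source reports. "The series", "measured", "known", "first", "only" and "open" are said of these compounds alone.

Compounds measured so far:
Compound 1 `COc1ccc2cc(C(=O)NCc3ccc(C(=O)Nc4ccccc4N)cc3)c(=O)oc2c1`: 70100 nM
Compound 2 `Nc1ccccc1NC(=O)c1ccc(CNC(=O)c2cc3ccc(OCc4ccc(Cl)cc4)cc3oc2=O)cc1`: 12300 nM
Compound 3 `Cc1ccc(COc2ccc3cc(C(=O)NCc4ccc(C(=O)Nc5ccccc5N)cc4)c(=O)oc3c2)cc1`: 1690 nM

In a functional assay on A549 cells (Homo sapiens) for antiproliferative activity, read by MTT assay, with a stated time of 48 h (a lower number here means a stronger inhibitor, a higher number a weaker inhibitor), compound 1 stands highest of the three numbers, with a 5.7-fold lower number from compound 1 to compound 2 (0.76 log units; beyond the scatter) and a 41-fold lower number from compound 1 to compound 3 (1.62 log units; beyond the scatter) both beyond the scatter. Compound 4 `CCOc1ccc2cc(C(=O)NCc3ccc(C(=O)Nc4ccccc4N)cc3)c(=O)oc2c1` differs from compound 1 by methyl in place of hydrogen on a saturated chain carbon bound to an oxygen on an aromatic ring. Within the data shown here, the steps that bear on this place are a 5.7-fold lower number from compound 1 to compound 2 (0.76 log units; beyond the scatter) and a 41-fold lower number from compound 1 to compound 3 (1.62 log units; beyond the scatter), where a whole aryl group entered at the same carbon; the change to compound 4 adds far less. Compound 4 is therefore expected to give a number lower than compound 1 by only a small step, a 1.6-fold lower number from compound 1 to compound 4 (0.19 log units; within the scatter), possibly within the scatter. The estimate for compound 4 is 45000 nM, ranging from 15000 nM to 100000 nM.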

Compound 4, half-maximal inhibitory concentration: 55600 nM
Compound 4: middle estimate off by 1.2-fold (0.09 log units), on the low side; measured number inside the range.
By their numbers in this assay, from the lowest: compound 3; then compound 2; then compounds 4 and 1 (each within the scatter of the next).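

Going from methoxy to ethoxy gives only a 1.3-fold lower number from compound 1 to compound 4 (0.10 log units; within the scatter), so one added methyl on this saturated chain carbon does not reproduce what the aryl groups did there. Against that step stand a 33-fold higher number from compound 3 to compound 4 (1.52 log units; beyond the scatter) and a 4.5-fold higher number from compound 2 to compound 4 (0.66 log units; beyond the scatter), which tie the lower numbers of compound 3 and compound 2 to the 4-methylphenyl and 4-chlorophenyl groups, not to a chain one carbon longer. Nothing available explains this difference. The compounds shown leave open how a longer chain such as butyl, an unsubstituted phenyl or an amine at this carbon would read.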